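A Pyrimidine for a Phenyl on the Thioether of Compound 1

The source may report more compounds than this note shows. Statements on the series, on what has been measured and on what is new or still open speak of the compounds shown alone.

The series rests on a shared core carrying a substituted thioether. In an assay on isolated protein for inhibition of retinal dehydrogenase 2 (Homo sapiens) (a higher number here means a weaker inhibitor, a lower number a stronger inhibitor), compound 1 `C[C@@H](Sc1nc2c(cnn2C)c(=O)n1-c1ccccc1)c1ccccc1` gives 40 nM, and compound 2 `CC(Sc1nc2nn(C3COC3)cc2c(=O)n1-c1ccccc1)c1cccnc1`, which differs from it in several places, gives 58 nM in this assay; the two numbers lie within the scatter of one another, so neither compound is set apart from the other.

Compound 3 `CC(Sc1nc2c(cnn2C)c(=O)n1-c1ccccc1)c1cncnc1` has not yet been measured. It differs from compound 1 in a single place: 1-(pyrimidin-5-yl)ethyl in place of 1-phenylethyl on a sulfur. Among the compounds with values here, no step between measured compounds isolates this change, and compound 2 cannot serve as a guide because its core also differs. The exchange of one ring for another of the same size is expected to shift this assay only modestly, if at all, and the estimated step of a 1.8-fold higher number from compound 1 to compound 3 (0.24 log units; within the scatter) is small. Compound 3 is thus expected to give 70 nM in this assay, within a range of 25 nM to 200 nM.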

Compound 3, half-maximal inhibitory concentration: 380 nM
Beside the measured number, compound 3's estimate is 5.4-fold (0.73 log units) below it; the whole stated range lies below it.
By their numbers in this assay, from the lowest: compounds 1 and 2 (each within the scatter of the next); then compound 3.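

The thioether position proves sensitive to the ring it carries. With the shared core held constant, 1-(pyrimidin-5-yl)ethyl in place of 1-phenylethyl on the sulfur gives a 9.5-fold higher number from compound 1 to compound 3 (0.98 log units; beyond the scatter) in this assay, although both groups have the same count of heavy atoms; the step also includes the loss of the defined stereocentre of compound 1, and the two contributions cannot be separated here. Nothing available explains the loss of inhibition.

As far as these compounds go, it remains open whether the ring nitrogens or the undefined stereocentre accounts for the step, and how each of the two stereoisomers of compound 3 would behave. Also open, from the compounds shown here alone, is how 1-(pyridin-3-yl)ethyl on the core of compound 1, or a methoxy group or chlorine on its phenyl ring, would fare.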